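This account rests on a few compounds, and the source may have more. Where it says the series, first, only, none or still open, it means among the compounds named here.

The measured compounds, with their results in a functional assay on NCI-H1299 cells (Homo sapiens) for antiproliferative activity, read by MTT assay, with a stated time of 48 h; on this read-out lower numbers stand for stronger inhibition and higher numbers for weaker inhibition:
Compound 1 `Cc1ccc2c(c1)C1(C(=O)N2Cc2ccccc2)C(C#N)=C(N)Oc2cc3oc(-c4ccccc4)cc(=O)c3c(O)c21` gives only a limit, > 50000 nM.
Compound 2 `Cc1cccc2c1N(Cc1ccccc1)C(=O)C21C(C#N)=C(N)Oc2cc3oc(-c4ccccc4)cc(=O)c3c(O)c21` gives only a limit, > 50000 nM.
Compound 3 `N#CC1=C(N)Oc2cc3oc(-c4ccccc4)cc(=O)c3c(O)c2C12C(=O)N(Cc1ccccc1)c1ccc(Cl)cc12` gives only a limit, > 50000 nM.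

All three share one core. Compound 3 differs from compound 1 by chloro in place of methyl on an aromatic carbon. The step that the two limits leave unreadable from compound 1 to compound 3 cannot be read in size because of the limit of > 50000 nM in this assay, at which 3 of the 3 values shown sit, so the change from methyl to chloro at that place tells nothing yet. Compound 2 has the same atoms as compound 1 joined differently; the difference between the two cores is not broken down here.

Compound 4 `N#CC1=C(N)Oc2cc3oc(-c4ccccc4)cc(=O)c3c(O)c2C12C(=O)N(Cc1ccccc1)c1c(Cl)cccc12` has not been measured. It differs from compound 2 by chloro in place of methyl on an aromatic carbon. This is the same kind of change as that from compound 1 to compound 3, but not the same: in compound 4 the place is ortho to a fused ring and meta to a fused ring, whereas in compound 3 it is meta to a fused ring and para to a fused ring.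

Among the compounds with values here, compound 4 is expected to stay near the limit as well, with an expected step that the limit leaves unreadable from compound 2 to compound 4, since every value so far sits at the limit of > 50000 nM in this assay, at which 3 of the 3 values shown sit. Compound 4 is therefore estimated at about 70000 nM, between 30000 nM and 200000 nM, most likely reported again as a limit.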

Compound 4, half-maximal inhibitory concentration: > 50000 nM
Compound 4: a limit, no number (the forecaster's own chance of this, stated with the estimate: 80%); the middle value is on the limit's open side.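

The change from methyl to chloro between compound 2 and compound 4 cannot be read in size, because both compounds give only a limit: (the limit of > 50000 nM in this assay, at which 4 of the 4 values shown sit). The compounds shown leave open whether methyl or chloro at either place makes any difference in this assay and what true value lies behind each limit.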